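Series notes: from compound 3 to compound 4

This account rests on a few compounds, and the source may have more. Where it says the series, first, only, none or still open, it means among the compounds named here.

In a functional assay for agonist activity at G protein-coupled receptor 88 (Homo sapiens), read by HTRF and cAMP accumulation (a lower number here means that less compound is needed, a higher number that more compound is needed for the effect), compound 3 `CCc1ccc(-c2ccc(N(C[C@@H](N)[C@@H](C)CC)C(=O)[C@@H]3C[C@H]3c3ccccc3)cc2)cc1` gives 44 nM, the lowest number among the three measured compounds. Compound 1 `CC[C@H](C)[C@H](N)CN(C(=O)[C@@H]1C[C@H]1c1cccc(Cl)c1)c1ccc(-c2ccccc2)cc1` gives 2200 nM and compound 2 `CC(C)C[C@H](N)CN(C(=O)[C@@H]1C[C@H]1c1ccccc1)c1ccc(-c2cccnc2)cc1` gives 10000 nM. Among the measured compounds shown here, both differ from compound 3 in more than one place, so their gaps to compound 3 show only that compound 3 sits well apart from each of them, beyond the scatter in both cases. Compound 4 `CC[C@H](C)[C@H](N)CN(C(=O)[C@@H]1C[C@H]1c1ccccc1)c1ccc(-c2ccc(NS(C)(=O)=O)cc2)cc1` is the next compound to be measured in this assay. Its change from compound 3 is methanesulfonamido in place of ethyl on an aromatic carbon. For the measured compounds named here, no pair of measured compounds differs in only one place, so no single-point step is available as a guide. Compound 4 is expected to sit at a higher number, beyond the scatter, the step being an 11-fold higher number from compound 3 to compound 4 (1.06 log units; beyond the scatter). Compound 4 is estimated at 500 nM in this assay, with a range from 100 nM to 3000 nM. Going by the values given here, the range is wide since the series offers no direct precedent for this change.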

Compound 4, half-maximal effective concentration: 1200 nM
Beside the measured number, compound 4's estimate is 2.4-fold (0.38 log units) below it; the measured number falls inside the stated range.
By their numbers in this assay, from the lowest: compound 3; then compounds 4 and 1 (each within the scatter of the next); then compound 2.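

In this assay, among the compounds shown here, the first change that can be read at a single place gives a large step, a 27-fold higher number from compound 3 to compound 4 (1.44 log units; beyond the scatter), with 4-(methanesulfonamido)phenyl in place of 4-ethylphenyl. The position, an aromatic carbon para to a large group, therefore does not treat these two groups alike, although one step cannot separate the effect of the larger group from that of its hydrogen-bond donor and acceptors. Nothing on record accounts for the size of this step.

From the compounds shown here alone, whether propyl, methoxy or a carboxylic acid at this carbon would stay close to compound 3 or move towards compound 4 remains open. Compound 1 and compound 2 differ from both of these compounds in more than one place, so their gaps cannot be read as steps.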